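The source may report more compounds than this note shows. Statements on the series, on what has been measured and on what is new or still open speak of the compounds shown alone.

Measured in a functional assay on HCT-116 cells (Homo sapiens) for cytotoxicity, read by MTT assay, with a stated time of 72 h; on this read-out higher numbers stand for weaker inhibition and lower numbers for stronger inhibition:
- Compound 1 `NCCCNc1c(C(=O)NCc2ccc(F)cc2)nc(Br)c2cccnc12`: 18000 nM
- Compound 2 `O=C(NCc1ccc(F)cc1)c1nc(Br)c2cccnc2c1NCc1ccc(F)cc1`: > 20000 nM (a limit)
- Compound 3 `O=C(NCCCNc1c(C(=O)NCc2ccc(F)cc2)nc(Br)c2cccnc12)c1ccccc1`: > 10000 nM (a limit)

Compound 3 has no exact value in this assay. Its result of > 10000 nM is a limit of the assay and not a number, so it gives only a loose starting point.

The next compound, compound 4 `CNc1c(C(=O)NCc2ccc(F)cc2)nc(Br)c2cccnc12`, trims the side chain of compound 3 down to its first carbon: hydrogen in place of 2-benzamidoethyl on a saturated chain carbon bound to a nitrogen on an aromatic ring. In words, this puts hydrogen in place of 2-benzamidoethyl on a saturated chain carbon bound to a nitrogen on an aromatic ring.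

Three measured steps involve this same side chain. The only one with any readable size is an at least 1.1-fold higher number from compound 1 to compound 2 (0.04 log units; that floor lies within the scatter). The other two, a step that the limit leaves unreadable from compound 1 to compound 3 and a step that the two limits leave unreadable from compound 2 to compound 3, cannot be sized. So no measured change to this chain has shown a clear gain in strength.

Among the measured compounds shown here, the expectation therefore rests mainly on compound 1, the only one with an exact value, at 18000 nM. No step beyond the scatter, in either direction, is expected, and the expected step is a step that the limit leaves unreadable from compound 3 to compound 4. The result may well be reported only as a limit. For compound 4, the estimated value is 20000 nM, with an expected range of 8000 nM to 40000 nM.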

Compound 4, half-maximal inhibitory concentration: > 20000 nM
Compound 4 gave a limit, no number (the forecaster's own chance of this, stated with the estimate: 60%); the middle value sits exactly at the limit.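

In this assay compound 4 is reported only as a limit, > 20000 nM, and that limit is not a number. Compound 2 carries the same limit, so neither hydrogen nor 4-fluorophenyl in this place gives a result that can be placed on the scale of this read-out: the limit of > 20000 nM in this assay, at which 2 of the 4 values shown sit. Among the compounds shown here, the one readable comparison is an at least 1.1-fold higher number from compound 1 to compound 4 (0.04 log units; that floor lies within the scatter), so losing the 2-aminoethyl group shows no real difference in strength, while the steps to compound 4 from compound 2 and compound 3 cannot be read.

As far as these compounds go, it remains open whether any group at this saturated chain carbon can bring the result clearly below that of compound 1, 18000 nM. A longer chain carrying an amine, or a chain carrying a carboxylic acid, would be a further test of this place, and any true differences among compound 2, compound 3 and compound 4 remain hidden behind their limits.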